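The source may hold more compounds than are shown below. What is called first, only, known or untested is meant among the compounds shown, and "the series" means these compounds.

Measured so far in a functional assay on K562 cells (Homo sapiens) for antiproliferative activity, read by trypan blue exclusion, with a stated time of 48 h, tested at 10 uM (on this read-out lower numbers stand for less inhibition of growth and higher numbers for more inhibition of growth at the one concentration tested), and nowhere else
- compound 1 `Cc1ccc(NC(=O)/C=C/c2ccccc2)c(C(N)=O)c1` gives 65.4% 
- compound 2 `NC(=O)c1cc(Br)ccc1NC(=O)/C=C/c1ccccc1` gives 62.4% 

Compound 2 at 62.4% lies within the usual scatter of compound 1 at 65.4% and the two cannot be told apart in this assay on these numbers.

The next compound is compound 3 `NC(=O)c1cc(I)ccc1NC(=O)/C=C/c1ccccc1` with the change iodo in place of bromo on an aromatic carbon in words iodo in place of bromo on an aromatic carbon, meta to a carbamoyl group and para to a large group.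

Within the data shown here, the only measured step that bears on this change is a number 3 percentage points lower from compound 1 to compound 2 (within the scatter) for bromo in place of methyl on an aromatic carbon, and on that small step no shift beyond the scatter is expected in this assay for the new change. Among the measured compounds shown here, no compound carrying iodo has been measured, so this expectation rests on thin evidence.

The estimated step is a number 0.6 percentage points higher from compound 2 to compound 3 (within the scatter) with its direction left open.

Compound 3 is estimated at 63% with an expected range from 52% to 74% at the single concentration tested.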

Compound 3, percent growth inhibition at one concentration: 74.5%
Estimate against measurement, compound 3: 11.5 percentage points below; the whole stated range lies below it.
By their numbers in this assay, from the lowest: compounds 2, 1 and 3 (each within the scatter of the next, the first and the last beyond it).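

In this assay this aromatic carbon, meta to a carbamoyl group and para to a large group, now shows a step that can be read: iodo in place of bromo gives a number 12.1 percentage points higher from compound 2 to compound 3 (beyond the scatter). Among these compounds, the same position with iodo in place of methyl gives a number 9.1 percentage points higher from compound 1 to compound 3 (within the scatter), so compound 3 separates from compound 2 but not from compound 1, and the three substituents do not fall into a clear ranking; the halogen exchange is the only change here that resolves beyond the scatter, and the earlier methyl to bromo step gave no sign of it. No measurement of any property accompanies these numbers, and the step stands without an explanation.

On these data alone, whether this position responds to other kinds of group stays open, for example a chloro or fluoro atom, a methoxy group, an amine or a carboxylic acid, any of which would show whether the difference between compound 2 and compound 3 belongs to a wider trend. Also open, as far as these compounds go, is whether that difference holds at concentrations other than the single one tested.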